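The compounds below may be only part of what the source reports. "The series", "measured", "known", "first", "only" and "open" are said of these compounds alone.

In an ADME assay on microsomes from liver (Mus musculus) for metabolic stability, read by LC-MS, with a stated time of 10 min (a higher number here means that more of the compound is left, a lower number that less of the compound is left), three compounds have been measured:
compound 1 `CN(C[C@H]1Cc2c(cccc2N2CCN(C3COC3)CC2)CN1)[C@H]1CCCc2cccnc21` gives 50.8%;
compound 2 `CCN(C[C@H]1Cc2c(cccc2N2CCNCC2)CN1)[C@H]1CCCc2cccnc21` gives 53.8%;
compound 3 `c1cnc2c(c1)CCC[C@@H]2N(CC1CCCCC1)C[C@H]1Cc2c(cccc2N2CCNCC2)CN1` gives 85.6%.

Compound 1 thus holds the lowest of the three numbers; compound 2 sits within the scatter of it, while compound 3 sits beyond it. Compound 4 `CN(C[C@H]1Cc2c(cccc2N2CCN(c3ccccn3)CC2)CN1)[C@H]1CCCc2cccnc21` differs from compound 1 by pyridin-2-yl in place of oxetan-3-yl on an amine nitrogen in a ring. Among the compounds with values here, the single measured step, a number 31.8 percentage points higher from compound 2 to compound 3 (beyond the scatter), concerns a change at a different place, on a saturated chain carbon bound to an amine nitrogen, not on the amine nitrogen in the ring, so no measured step bears on the exchange made here. The expectation in this assay is therefore no step beyond the scatter, that is a number 0.8 percentage points lower from compound 1 to compound 4 (within the scatter). For compound 4 the estimate in this assay is 50%, within a range from 30% to 70%.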

Compound 4, percent of the compound remaining: 46.1%
Compound 4: the middle estimate sits 3.9 percentage points above what was measured, and the stated range covers the measured number.
By their numbers in this assay, from the lowest: compounds 4, 1 and 2 (each within the scatter of the next); then compound 3.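

In this assay, the exchange on the amine nitrogen in a ring, pyridin-2-yl in place of oxetan-3-yl, gave a number 4.7 percentage points lower from compound 1 to compound 4 (within the scatter). At this position, a six-membered aromatic ring and a four-membered non-aromatic ring thus stand within the scatter of each other, whereas the step at the saturated chain carbon, a number 31.8 percentage points higher from compound 2 to compound 3 (beyond the scatter), lies beyond it. No available evidence accounts for this result.

As far as these compounds go, whether an acetyl group or a longer alkyl chain on this nitrogen would behave the same remains open. So does whether pyridin-2-yl would give a similar number alongside the cyclohexyl of compound 3.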